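One Methyl Removed From an Amide

This account rests on a few compounds, and the source may have more. Where it says the series, first, only, none or still open, it means among the compounds named here.

Within the data shown here, in a functional assay on MCF7 cells (Homo sapiens) for antiproliferative activity, read by CCK-8 assay, with a stated time of 72 h (a lower number here means a stronger inhibitor of growth, a higher number a weaker inhibitor of growth), compound 1 (`CCC1C(=O)N(C)c2cnc(-n3ccc4cc(C(=O)NC)ccc43)nc2N1c1ccn(C)n1`) gives 35400 nM and is the only compound here with a number. Compound 2 (`CC[C@@H]1C(=O)N(C)c2cnc(-n3ccc4cc(F)ccc43)nc2N1C1CCCC1`) is recorded as "not active" (no number reported) and so cannot be ranked against it on a numerical scale. Going by these compounds, a single number offers no series to compare with, so the standing of compound 1 stays open.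

Compound 3 (`CCC1C(=O)N(C)c2cnc(-n3ccc4cc(C(N)=O)ccc43)nc2N1c1ccn(C)n1`) puts hydrogen in place of methyl on an amide-type nitrogen, which also reads as methylcarbamoyl to carbamoyl. Among the measured compounds shown here, no measured pair shows what this change does, so any forecast here is loose. In this assay the expectation is no shift beyond the usual scatter, with neither direction clearly favoured. The estimate is a 1.2-fold lower number from compound 1 to compound 3 (0.07 log units; within the scatter) and remains an expectation only. Compound 3 is expected at 30000 nM (estimated range 9000 nM to 90000 nM).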

Compound 3, concentration for 50% growth inhibition: "not active" (no number reported)
The entry for compound 3 holds no number; no gap can be computed for the estimate.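

Among these compounds, compound 3 is recorded as "not active" in this assay with no number, so no step from compound 1 to compound 3 can be read, and no evidence bears on this result. Going by these compounds, whether swapping methyl for hydrogen on this amide nitrogen changes growth inhibition remains open.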